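This account rests on a few compounds, and the source may have more. Where it says the series, first, only, none or still open, it means among the compounds named here.

Compound 1, `O=C(O)CCn1c2ccc([N+](=O)[O-])cc2c(=O)n1Cc1ccccc1`, has no result in an ADME assay on Vero cells (Chlorocebus sabaeus) for inhibition, read by fluorescence and resazurin assay, with a stated time of 24 h (a higher number here means that more compound is tolerated, a lower number that less compound is tolerated), its entry there reading "not determined" (no result reported). Compound 2, `CN(C)C(=O)CCCn1c2ccc([N+](=O)[O-])cc2c(=O)n1Cc1ccccc1`, differs from it in carrying a longer chain that ends in a dimethylamide. In this assay compound 2 reaches only a limit of the assay, > 300000 nM, and no single number. Compound 2 thus stands at the limit of > 300000 nM in this assay, at which 1 of the 2 values shown sits, the top of what the assay reports, with the only other entry giving no number at all. Compound 3, `O=c1c2cc([N+](=O)[O-])ccc2n(CCO)n1Cc1ccccc1`, is the next compound; relative to compound 2 it shows the change (hydroxy in place of (dimethylcarbamoyl)methyl on a saturated chain carbon, two bonds along the chain from an aromatic nitrogen). Among the compounds with values here, no measured pair differs in one place, so there is no step to lean on. The step from compound 2 to compound 3 is expected to be a number no higher from compound 2 to compound 3 (the limit leaves the size open), that is, none beyond the scatter. Compound 3 is expected to give about 300000 nM in this assay, in the range 100000 nM to 1000000 nM, most likely again as a limit.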

Compound 3, half-maximal cytotoxic concentration: > 300000 nM
Compound 3: no number, only a limit; the forecaster's own chance of this, stated with the estimate: 70%; the middle value sits exactly at the limit.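

Compound 2 and compound 3 both end at a limit in this assay, and no step can be read between them. The compounds shown leave open where the half-maximal cytotoxic concentration of either compound lies, and whether hydroxy in place of (dimethylcarbamoyl)methyl changes it at all.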